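Swapping an amine substituent on a shared quinone core

The compounds below may be only part of what the source reports. "The series", "measured", "known", "first", "only" and "open" are said of these compounds alone.

The study concerns two measured compounds and one awaiting measurement in a functional assay on MGC-803 cells (Homo sapiens) for inhibition, read by sulforhodamine B assay; on this read-out higher numbers stand for weaker inhibition and lower numbers for stronger inhibition. Compound 1 `O=C1C=C(NC2CCCCC2)C(=O)c2c1nc1n2[C@H]2OC[C@@H](O)[C@H]2OC1` carries a cyclohexyl group on the amine nitrogen. In this assay compound 1 gives > 8000 nM, which is a limit of the assay rather than a number. That limit is documented as the limit of > 8000 nM in this assay, at which 1 of the 2 values shown sits. Compound 2 `COc1ccccc1NC1=CC(=O)c2c(nc3n2[C@H]2OC[C@@H](O)[C@H]2OC3)C1=O` carries a 2-methoxyphenyl group on the same nitrogen, and in this assay compound 2 gives 1670 nM. Within the data shown here, the two values therefore show compound 2 as the more strongly inhibiting of the pair, though no direct step between them is recorded.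

Compound 3 `COc1cccc(NC2=CC(=O)c3nc4n(c3C2=O)[C@H]2OC[C@@H](O)[C@H]2OC4)c1` is still to be measured. It differs from compound 1 as follows: 3-methoxyphenyl in place of cyclohexyl on an amine nitrogen. Cut one bond further out, the change reads cyclohexylamino to (3-methoxyphenyl)amino.

Compound 1 reached only a limit of the assay. Compound 2, with its aromatic amine substituent, measured 1670 nM. On that basis the step of an at least 4.0-fold lower number from compound 1 to compound 3 (0.60 log units; beyond the scatter) is expected to run toward stronger inhibition, beyond the scatter. Compound 3 is expected to give about 2000 nM, with a range from 600 nM to 7000 nM.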

Compound 3, half-maximal inhibitory concentration: 1780 nM
Compound 3: the middle estimate sits 1.1-fold (0.05 log units) above what was measured; low and high end bracket the measured number.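

Setting 3-methoxyphenyl in place of cyclohexyl on the amine nitrogen gives, in this assay, an at least 4.4-fold lower number from compound 1 to compound 3 (0.65 log units; beyond the scatter), the first step at this position that can be read directly, and it runs toward stronger inhibition. Compound 2, with 2-methoxyphenyl, gives 1670 nM and compound 3, with 3-methoxyphenyl, gives 1780 nM; these values lie within the usual scatter of each other, so this read-out does not separate the two groups. Compound 1 stands at a limit of the assay and not at a number, so the step has a lower bound but no known full size: the limit of > 8000 nM in this assay, at which 1 of the 3 values shown sits.

From the compounds shown here alone, what an unsubstituted phenyl on the same nitrogen would give remains open, and with it whether the methoxy group contributes anything to the stronger inhibition or the aromatic ring alone accounts for it. Also open, going by these compounds, is how a 4-methoxyphenyl or a benzyl group at this place would read in this assay, and whether an open-chain amine substituent would fall nearer to compound 1 or to compound 3.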